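This account rests on a few compounds, and the source may have more. Where it says the series, first, only, none or still open, it means among the compounds named here.

Three compounds share one core, an amide built from an aromatic amine that carries a hexafluoro-substituted alcohol, and differ only in the aromatic group attached to the carbonyl carbon. Compound 1 `Cc1cccc(C(=O)Nc2c(C(O)(C(F)(F)F)C(F)(F)F)ccc3ccccc23)c1` gives 52.5 nM in a functional assay (Sus scrofa) with sulfonylurea receptors; K-ATP channels (Homo sapiens) as the target; a higher number here means that more compound is needed for the effect, a lower number that less compound is needed. Compound 2 `N#Cc1cccc(C(=O)Nc2c(C(O)(C(F)(F)F)C(F)(F)F)ccc3ccccc23)c1` gives 372 nM in this assay, and compound 3 `O=C(Nc1c(C(O)(C(F)(F)F)C(F)(F)F)ccc2ccccc12)c1ccc(Cl)cc1` gives 389 nM. Compound 3 therefore holds the highest of the three numbers, although the gap a 1.0-fold higher number from compound 2 to compound 3 (0.02 log units; within the scatter) places it level with compound 2, while the gap a 7.4-fold higher number from compound 1 to compound 3 (0.87 log units; beyond the scatter) sets it clearly apart from compound 1.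

Compound 4 `O=C(Nc1c(C(O)(C(F)(F)F)C(F)(F)F)ccc2ccccc12)c1ccco1` has not yet been measured. It differs from compound 3 by furan-2-yl in place of 4-chlorophenyl on a carbonyl carbon. The two measured steps that touch the same position, a 7.4-fold higher number from compound 1 to compound 3 (0.87 log units; beyond the scatter) and a 1.0-fold higher number from compound 2 to compound 3 (0.02 log units; within the scatter), show that exchanging the aryl group on the carbonyl carbon can shift this assay modestly or not at all. No furan has been measured here, so compound 4 is expected to stay near compound 3, with a 1.0-fold higher number from compound 3 to compound 4 (0.01 log units; within the scatter) as the estimated step, giving an estimate of 400 nM and a range from 120 nM to 1300 nM.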

Compound 4, half-maximal effective concentration: 182 nM
For compound 4 the middle estimate is 2.2-fold (0.34 log units) above the measured one; low and high end bracket the measured number.
By their numbers in this assay, from the lowest: compound 1; then compound 4; then compounds 2 and 3 (each within the scatter of the next).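

Putting furan-2-yl on the carbonyl carbon shows that this place accepts a five-membered aromatic ring with a hetero atom, and that this smaller group can give a lower number than two of the six-membered aromatic rings: in this assay the exchange gives a 2.1-fold lower number from compound 3 to compound 4 (0.33 log units; beyond the scatter) and also a 2.0-fold lower number from compound 2 to compound 4 (0.31 log units; beyond the scatter) in the same direction. It does not match 3-methylphenyl, however, with a 3.5-fold higher number from compound 1 to compound 4 (0.54 log units; beyond the scatter) as the remaining gap. The earlier compounds shown here gave only two levels, whereas compound 4 now adds a third level, so aromatic groups on the carbonyl carbon can produce intermediate numbers.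

Nothing available here explains why the numbers shift with these groups. It also remains open where a thiophene or a pyridine ring on the carbonyl carbon would fall among these levels.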